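The compounds below may be only part of what the source reports. "The series", "measured", "known", "first", "only" and "open" are said of these compounds alone.

Compound 1, `Cc1cccc(-n2nncc2CN2C(=O)C3(C(C#N)=C(N)Oc4c3c3nc5ccccc5nc3c3ccccc43)c3ccccc32)c1`. In a functional assay on HepG2 cells (Homo sapiens) for antiproliferative activity, read by MTT assay, with a stated time of 48 h (on this read-out lower numbers stand for stronger inhibition and higher numbers for weaker inhibition), compound 1 gives only a limit, > 50000 nM.
Compound 2, `CCOc1ccc(-n2nncc2CN2C(=O)C3(C(C#N)=C(N)Oc4c3c3nc5ccccc5nc3c3ccccc43)c3ccccc32)cc1`. In this assay compound 2 likewise gives only a limit, > 50000 nM.

Among the compounds with values here, compound 2 therefore stands nowhere on a readable scale: its result in this assay is a limit, and the one other value shown is a limit too. Within the data shown here, the single measured step, a step that the two limits leave unreadable from compound 1 to compound 2, cannot be read in size or direction, since both ends rest on (the limit of > 50000 nM in this assay, at which 2 of the 2 values shown sit). Compound 3, `N#CC1=C(N)Oc2c(c3nc4ccccc4nc3c3ccccc23)C12C(=O)N(Cc1cnnn1-c1cccc(S(N)(=O)=O)c1)c1ccccc12`, differs from compound 2 in one place: 3-sulfamoylphenyl in place of 4-ethoxyphenyl on an aromatic nitrogen. Among the measured compounds shown here, no measured step bears on this change in a way that can be sized, and the only comparison available, between compound 1 and compound 2, shows two limits and nothing more. The expectation for compound 3 in this assay is accordingly that it will again come out at the limit, with no change beyond the scatter, a step that the limit leaves unreadable from compound 2 to compound 3. Compound 3 is estimated at 60000 nM, within a range from 20000 nM to 200000 nM, most probably reported as a limit only.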

Compound 3, half-maximal inhibitory concentration: 21500 nM
Beside the measured number, compound 3's estimate is 2.8-fold (0.45 log units) above it; the measured number falls inside the stated range.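

With 3-sulfamoylphenyl on the aromatic nitrogen, compound 3 is the first compound shown to give a number rather than a limit in this assay, so a change at this position can move the read-out, which compound 1 and compound 2 could not show. Replacing 4-ethoxyphenyl with 3-sulfamoylphenyl gives an at least 2.3-fold lower number from compound 2 to compound 3 (0.36 log units; beyond the scatter), and sulfamoyl in place of methyl on an aromatic carbon gives an at least 2.3-fold lower number from compound 1 to compound 3 (0.36 log units; beyond the scatter). Both steps are bounds and not sizes, since one end of each rests on a limit: the limit of > 50000 nM in this assay, at which 2 of the 3 values shown sit.

The step between the two compounds at the limit remains unreadable, so the compounds shown do not tell how 3-methylphenyl and 4-ethoxyphenyl rank against each other. They also leave open whether the sulfamoyl group itself is needed, or whether a carboxylic acid or an amine in its place on the same phenyl ring would also give a number rather than a limit, and how such a number would stand against that of compound 3.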